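Ring size on the aminomethyl side chain of the core

The compounds below may be only part of what the source reports. "The series", "measured", "known", "first", "only" and "open" are said of these compounds alone.

Going by the values given here, compound 1 `N#Cc1cnc(NCc2cnccc2C(F)(F)F)cc1NC[C@H]1C[C@H](O)C1` gives 700 nM in an assay on isolated protein for inhibition of protein kinase C theta type (Homo sapiens), read by TR-FRET, with a stated time of 2 h (a lower number here means a stronger inhibitor, a higher number a weaker inhibitor), the higher of the two numbers measured so far. Among the compounds with values here, compound 2 `N#Cc1cnc(NCc2cnccc2C(F)(F)F)cc1N[C@H]1CC[C@@H](O)CC1` gives 100 nM in this assay; the single measured step, a 7.0-fold lower number from compound 1 to compound 2 (0.85 log units; beyond the scatter), is the only comparison that bears on the change at hand. Compound 3 `N#Cc1cnc(NCc2cnccc2C(F)(F)F)cc1NC[C@H]1CC[C@H](O)CC1` differs from compound 1 by 4-hydroxycyclohexyl in place of 3-hydroxycyclobutyl on a saturated chain carbon bound to a nitrogen on an aromatic ring, so the link through a saturated chain carbon to the nitrogen remains, which compound 2 does not have. The measured step supports a lower number for the larger ring, yet it also folds in the loss of that link, for which no separate measurement exists in this set. The expected movement is therefore in the same direction but smaller, a 2.8-fold lower number from compound 1 to compound 3 (0.45 log units; beyond the scatter). Compound 3 is estimated at 250 nM in this assay, with a range from 80 nM to 800 nM.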

Compound 3, half-maximal inhibitory concentration: 50 nM
Beside the measured number, compound 3's estimate is 5.0-fold (0.70 log units) above it; measured number outside the range, below it.
By their numbers in this assay, from the lowest: compounds 3 and 2 (each within the scatter of the next); then compound 1.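

With the link through the saturated chain carbon kept, the change from 3-hydroxycyclobutyl to 4-hydroxycyclohexyl alone gives a 14-fold lower number from compound 1 to compound 3 (1.15 log units; beyond the scatter) in this assay, so the larger ring is now measured apart from any change in the link. With 4-hydroxycyclohexyl in both compounds, adding the link gives a 2.0-fold lower number from compound 2 to compound 3 (0.30 log units; within the scatter), so this pair shows no separable effect of the link. No measurement here explains why the larger ring gives the lower number.

Going by these compounds, all three compounds carry a hydroxyl on the ring, so its contribution stays open; plain cyclohexyl or 4-aminocyclohexyl would address that. Also open, on these data alone, are the effects of a longer chain between ring and nitrogen and of the other ring stereoisomer of (4-hydroxycyclohexyl)methyl.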